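Ethoxy in Place of Benzyl on an Angiotensin Receptor Ligand

The source may report more compounds than this note shows. Statements on the series, on what has been measured and on what is new or still open speak of the compounds shown alone.

Compound 3 `CCc1nc2c(C)cc(C)nc2n1Cc1ccc(OC(C(=O)O)c2ccccc2)c(Cc2ccccc2)c1` gives 800 nM in an assay on Midbrain with Type-2 angiotensin II receptor (Rattus norvegicus) as the target (on this read-out lower numbers stand for stronger inhibition and higher numbers for weaker inhibition), the second highest of the three numbers. Compound 1 `CCc1nc2c(C)cc(C)nc2n1Cc1ccc(OC(C(=O)O)c2ccccc2)c(C)c1` gives 940 nM, a value within the scatter of compound 3, and compound 2 `C=CCc1cc(Cn2c(CC)nc3c(C)cc(C)nc32)ccc1OC(C(=O)O)c1ccccc1` gives 270 nM. The measured steps are a 1.2-fold lower number from compound 1 to compound 3 (0.07 log units; within the scatter), a 3.0-fold higher number from compound 2 to compound 3 (0.47 log units; beyond the scatter) and a 3.5-fold lower number from compound 1 to compound 2 (0.54 log units; beyond the scatter). Compound 4 `CCOc1cc(Cn2c(CC)nc3c(C)cc(C)nc32)ccc1OC(C(=O)O)c1ccccc1` carries ethoxy in place of benzyl on an aromatic carbon. Going by the values given here, no measured step introduces an ethoxy group, so the change is unprecedented in this set; the measured steps at this position were at most modest. A modest move in either direction is therefore expected, and compound 4 is estimated to shift by a 1.5-fold lower number from compound 3 to compound 4 (0.16 log units; within the scatter). In this assay compound 4 is expected to give 550 nM, with a likely range from 200 nM to 1500 nM.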

Compound 4, half-maximal inhibitory concentration: 1200 nM
Compound 4: the middle estimate sits 2.2-fold (0.34 log units) below what was measured, within the range that was stated.
By their numbers in this assay, from the lowest: compound 2; then compounds 3, 1 and 4 (each within the scatter of the next).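

Ethoxy in place of benzyl brings a 1.5-fold higher number from compound 3 to compound 4 (0.18 log units; within the scatter) and ethoxy in place of methyl brings a 1.3-fold higher number from compound 1 to compound 4 (0.11 log units; within the scatter) in this assay and so is not told apart from either group at this aromatic carbon. Ethoxy in place of allyl brings a 4.4-fold higher number from compound 2 to compound 4 (0.65 log units; beyond the scatter) and leaves allyl as the only one of the four groups here that stands apart from the others. Nothing available accounts for this difference. Going by these compounds, whether propyl, a longer chain, an amine or a hydroxyl at this carbon would match allyl stays open.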